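Replacing the dimethylpiperazine on the shared core with a dimethylaminopiperidine

The compounds below may be only part of what the source reports. "The series", "measured", "known", "first", "only" and "open" are said of these compounds alone.

Of the compounds shown here, three with the same core have been measured in an ADME assay on a cell-free system (plasma, Rattus norvegicus) for protein binding; on this read-out higher numbers stand for a larger free fraction and lower numbers for a smaller free fraction. Compound 1 `COc1cc2nnc(C(N)=O)c(Nc3ccc(C)cc3F)c2cc1N1CCN(C)CC1` gives 0.063. Compound 2 `COc1cc2nnc(C(N)=O)c(Nc3ccc(C)cc3F)c2cc1N1CCCN(C)CC1` gives 0.103. Compound 3 `COc1cc2nnc(C(N)=O)c(Nc3ccc(C)cc3F)c2cc1N1C[C@@H](C)N[C@@H](C)C1` gives 0.013, the lowest of the three numbers; its nearest neighbour is compound 1, and the gap a 4.8-fold lower number from compound 1 to compound 3 (0.69 log units; beyond the scatter) lies beyond the scatter, as does a 7.9-fold lower number from compound 2 to compound 3 (0.90 log units; beyond the scatter). The step from compound 1 to compound 2, a 1.6-fold higher number from compound 1 to compound 2 (0.21 log units; within the scatter), stays within the scatter.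

Compound 4 `COc1cc2nnc(C(N)=O)c(Nc3ccc(C)cc3F)c2cc1N1CCC(N(C)C)CC1` has not yet been measured. It differs from compound 3 in one place: 4-(dimethylamino)piperidin-1-yl in place of 3,5-dimethylpiperazin-1-yl on an aromatic carbon. For the measured compounds named here, the only steps that bear on this change are the two that lead into compound 3, each a modest fall in the free fraction on going from a ring carrying no hydrogen-bond donor to the 3,5-dimethylpiperazin-1-yl ring. Since compound 4 again carries a ring with no hydrogen-bond donor, the reverse movement is expected, so that the step from compound 3 to compound 4 in this assay is estimated at a 4.6-fold higher number from compound 3 to compound 4 (0.66 log units; beyond the scatter). Compound 4 is therefore expected to give 0.06, within a range of 0.025 to 0.14.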

Compound 4, unbound fraction: 0.15
Estimate against measurement, compound 4: 2.5-fold (0.40 log units) below, and the stated range ends below it.
By their numbers in this assay, from the lowest: compound 3; then compounds 1, 2 and 4 (each within the scatter of the next, the first and the last beyond it).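

Read in this assay, a 12-fold higher number from compound 3 to compound 4 (1.06 log units; beyond the scatter) is the largest step in the set, so a single exchange at this aromatic carbon can shift the free fraction much further than the earlier steps did. For the compounds shown here, the new ring also does more than restore the level of the other rings: a 2.4-fold higher number from compound 1 to compound 4 (0.38 log units; beyond the scatter) lies beyond the scatter, while a 1.5-fold higher number from compound 2 to compound 4 (0.16 log units; within the scatter) stays within it, which leaves compound 3, the one compound here with a hydrogen-bond donor in this ring, alone at the low end. Nothing among the data gives a cause for these steps.

With only compound 3 carrying that donor, the compounds shown cannot separate the ring hydrogen from its two methyl groups or its defined stereocentres. Also open, on these data alone, is where an unsubstituted piperazin-1-yl or a morpholin-4-yl ring would fall.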